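Shortening a nitrooxy-bearing ester chain in a cytotoxicity series

The source may hold more compounds than are shown below. What is called first, only, known or untested is meant among the compounds shown, and "the series" means these compounds.

This account concerns two measured esters and a third, not yet measured, that is built from the second. In a functional assay on HOP-62 cells (Homo sapiens) for cytotoxicity, read by resazurin assay, with a stated time of 72 h (a lower number here means a stronger inhibitor, a higher number a weaker inhibitor), compound 1 `O=C(/C=C/c1ccc(O)c(O)c1)OCc1c(-c2ccccc2)no[n+]1[O-]` gives 6120 nM. Compound 2 `COc1cc(/C=C/C(=O)OC/C=C/CO[N+](=O)[O-])ccc1O` gives 5130 nM in this assay, the lower of the two numbers recorded so far; the gap to compound 1 lies within the scatter, so the two values are treated as alike and no order is claimed between them.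

Compound 3 `COc1cc(/C=C/C(=O)OCCCO[N+](=O)[O-])ccc1O` is the next step. Relative to compound 2 it carries a 2-(nitrooxy)ethyl group in place of the longer chain, on a saturated chain carbon bound to an oxygen next to a carbonyl group (a group of 6 heavy atoms (2 carbon, 1 nitrogen, 3 oxygen; no ring) in place of a group of 7 heavy atoms (3 carbon, 1 nitrogen, 3 oxygen; no ring), on a saturated chain carbon bound to an oxygen next to a carbonyl group). For the measured compounds named here, no measured pair in this set shows a step of this kind, so there is no directly comparable change to lean on.

On the evidence available, the writer expects the step of a 1.1-fold higher number from compound 2 to compound 3 (0.03 log units; within the scatter) to be small, with no direction beyond the scatter. Compound 3 is therefore estimated at 5500 nM in this assay, with a range from 2500 nM to 12000 nM.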

Compound 3, half-maximal inhibitory concentration: 19400 nM
Estimate against measurement, compound 3: 3.5-fold (0.55 log units) below; the measured number lies above the stated range.
By their numbers in this assay, from the lowest: compounds 2 and 1 (each within the scatter of the next); then compound 3.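

For the compounds shown here, this position, on a saturated chain carbon bound to an oxygen next to a carbonyl group, proves sensitive to the chain it carries: in this assay the 2-(nitrooxy)ethyl group brings a 3.8-fold higher number from compound 2 to compound 3 (0.58 log units; beyond the scatter) and this modest step, beyond the scatter, is the first single-place change in the set. The group that leaves has 7 heavy atoms and 2 double bonds outside aromatic rings, while the group that enters has 6 heavy atoms and 1 such double bond; their hydrogen-bond donor and acceptor counts and net charge are the same, and this one pair cannot separate the two differences. Nothing at hand accounts for the size or direction of the step.

The compounds shown leave open whether the loss of the chain double bond or the change in heavy atoms matters more, and how a longer chain would fare at this position. They also leave open whether an amine or a carboxylic acid at the end of the chain, in place of the nitrooxy group, would be tolerated in this assay on the same core.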